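The source may hold more compounds than are shown below. What is called first, only, known or untested is meant among the compounds shown, and "the series" means these compounds.

Of the compounds shown here, three have so far been measured in a functional assay on the whole organism (strain Swiss) with Mus musculus as the target, in the maximal electroshock model, with a stated time of 0.5 h, at a dose of 100 mg/kg by the intraperitoneal route; a higher number here means a stronger effect of the compound at the dose given, a lower number a weaker effect. Compound 1 `COCC(C(=O)N1CCN(c2cccc(C(F)(F)F)c2)CC1)N1C(=O)CCC1=O` gives 75% in this assay. Compound 2 `CC(C(=O)N1CCN(c2ccc(Cl)cc2)CC1)N1C(=O)CCC1=O` gives 25% in this assay, and compound 3 `CC(C(=O)N1CCN(c2ccccc2C(F)(F)F)CC1)N1C(=O)CCC1=O` gives 25%. Compound 2 therefore stands level with compound 3 at the digits shown, the two together forming the bottom of the three numbers; its nearest neighbour is compound 3, with no change within the scatter, and its furthest is compound 1, whose number lies higher by an amount beyond the scatter. For the measured compounds named here, compound 1 differs from compound 2 in more than one place, so no step between measured compounds that changes only one site is available, and the weight of the aryl group alone cannot be read off.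

The next compound, compound 4 `CC(C(=O)N1CCN(c2cccc(F)c2)CC1)N1C(=O)CCC1=O`, awaits measurement in this assay. Relative to compound 2 the change is 3-fluorophenyl in place of 4-chlorophenyl on an amine nitrogen in a ring. Going by the values given here, a modest rise is expected from this change, because compound 1 with 75% is the only compound clearly apart from the others, though it also carries a different chain beside the amide. Compound 4 is expected to give 40% in this assay, within 15% to 70%. The estimated step is a number 15 percentage points higher from compound 2 to compound 4 (beyond the scatter), which the scatter may well swallow.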

Compound 4, a percentage reported as activity, at one dose (the size of the read-out at that dose, not a potency): 0%
Compound 4: middle estimate off by 40 percentage points, on the high side, and the stated range ends above it.
By their numbers in this assay, from the lowest: compound 4; then compounds 2 and 3 (each within the scatter of the next); then compound 1.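

In this assay, for the compounds shown here, putting 3-fluorophenyl in place of 4-chlorophenyl on an amine nitrogen in a ring gives a number 25 percentage points lower from compound 2 to compound 4 (beyond the scatter), the first step in this set in which only one place changes. The aryl group on this nitrogen therefore matters on its own: with the rest of the structure held constant, the read-out moves beyond the scatter, and compound 4 gives 0% at the dose tested. The two aryl groups match in heavy-atom count and in having no hydrogen-bond donors or acceptors, and no measurement here explains why the read-out nevertheless differs.

This single step changes both the halogen and where it sits on the phenyl ring, so the compounds shown cannot say which of the two changes carries the effect. Going by these compounds, it also remains open how this series would respond to an unsubstituted phenyl group or to a methoxy group on the phenyl ring at this same nitrogen.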